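The compounds below may be only part of what the source reports. "The series", "measured", "known", "first", "only" and "open" are said of these compounds alone.

The series rests on a shared core, first seen in compound 1 `COc1ccc(/C=C/S(=O)(=O)Cc2ccc(OC)cc2)cc1`. In a functional assay on H157 cells (Homo sapiens) for antiproliferative activity, read by trypan blue exclusion (a lower number here means a stronger inhibitor, a higher number a weaker inhibitor), compound 1 gives only a limit of the assay, > 20000 nM. Compound 2 `COc1ccc(CS(=O)(=O)/C=C/c2ccccc2OC)cc1` carries its methoxy elsewhere on the ring, and in this assay compound 2 gives 5000 nM. Compound 3 `COc1ccc(CS(=O)(=O)/C=C/c2ccc(OC)cc2OC)cc1` joins both methoxy groups on that ring. In this assay compound 3 gives only a limit of the assay, > 20000 nM. Compound 3 thus stands at the limit of > 20000 nM in this assay, at which 2 of the 3 values shown sit, where no number can be read off.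

Compound 4 `COc1ccc(CS(=O)(=O)/C=C/c2cc(OC)c(OC)cc2OC)cc1` differs from compound 3 by methoxy in place of hydrogen on an aromatic carbon. Two measured steps of the same kind bear on it: an at least 4.0-fold higher number from compound 2 to compound 3 (0.60 log units; beyond the scatter) and a step that the two limits leave unreadable from compound 1 to compound 3. Neither gives a readable size from a limit onward, so no step beyond the scatter can be expected in this assay in either direction, and a further limit is the likeliest outcome.

Compound 4 is therefore estimated at 25000 nM, with a range from 8000 nM to 80000 nM. This estimate corresponds to an expected step that the limit leaves unreadable from compound 3 to compound 4, which is expected to lie within the scatter.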

Compound 4, half-maximal inhibitory concentration: > 20000 nM
Compound 4 was reported as a limit; the forecaster's own chance of this, stated with the estimate: 75%; the middle value is on the limit's open side.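

In this assay compound 4 gives only a limit, > 20000 nM. Compound 3 is a limit too, so no step can be read between compound 3 and compound 4: the limit of > 20000 nM in this assay, at which 3 of the 4 values shown sit. The compounds shown leave open whether this added methoxy changes the number at all.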